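This account rests on a few compounds, and the source may have more. Where it says the series, first, only, none or still open, it means among the compounds named here.

Compound 1 `O=C(Nc1ccc(Cl)cc1)N1CCC[C@H]1c1nc(-c2ccccc2Cl)no1`: > 50000 nM as a limit
Compound 2 `Cc1ccc(-c2noc([C@@H]3CCCN3C(=O)Nc3ccc(Cl)cc3)n2)cc1`: > 50000 nM as a limit

In an ADME assay on MCF-10A cells (Homo sapiens) for inhibition, with a stated time of 48 h (on this read-out lower numbers stand for stronger inhibition and higher numbers for weaker inhibition), compound 2 gives > 50000 nM as a limit of the assay and not a number. Going by the values given here, the series so far shows the limit of > 50000 nM in this assay, at which 2 of the 2 values shown sit, and no readable number. Compound 3 `O=C(Nc1ccc(Cl)cc1)N1CCC[C@H]1c1nc(-c2ccc(Cl)cc2)no1` has chloro in place of methyl on an aromatic carbon, para to a large group (chloro in place of methyl on an aromatic carbon) and otherwise matches compound 2. Among the compounds with values here, the only measured step (a step that the two limits leave unreadable from compound 1 to compound 2) gives no size to carry over, so no step beyond the scatter is expected in this assay here. The expected change is a number no higher from compound 2 to compound 3 (the limit leaves the size open) as an estimate. For compound 3 the estimated value is 50000 nM with an expected range of 25000 nM to 100000 nM and a report as a limit is the likeliest outcome.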

Compound 3, half-maximal inhibitory concentration: > 50000 nM
Compound 3: no number, only a limit (the forecaster's own chance of this, stated with the estimate: 85%); the middle value sits exactly at the limit.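

No step can be read among compound 1, compound 2 and compound 3, which each give only a limit in this assay: the limit of > 50000 nM in this assay, at which 3 of the 3 values shown sit.

The compounds shown leave open whether changing the substituent on the phenyl group alters inhibition at all, and by how much.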